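Aryl replacement on the ring nitrogen: compound 3 to compound 4

The compounds below may be only part of what the source reports. "The series", "measured", "known", "first", "only" and "open" are said of these compounds alone.

The three measured compounds share one core and differ only in the aryl group on the aromatic nitrogen: compound 1 `O=C(Nc1ccc(Oc2ccnc3[nH]ccc23)c(F)c1)c1cn(-c2ccccc2)c2ccccc2c1=O`, compound 2 `O=C(Nc1ccc(Oc2ccnc3[nH]ccc23)c(F)c1)c1cn(-c2ccc(Br)cc2)c2ccccc2c1=O` and compound 3 `O=C(Nc1ccc(Oc2ccnc3[nH]ccc23)c(F)c1)c1cn(-c2ccc(Br)cc2F)c2ccccc2c1=O`. In a functional assay on HepG2 cells (Homo sapiens) for inhibition, read by MTT assay, with a stated time of 72 h (on this read-out lower numbers stand for stronger inhibition and higher numbers for weaker inhibition), compound 1 gives 760 nM, compound 2 gives 710 nM and compound 3 gives 2200 nM. Compound 3 thus stands as the highest of the three numbers, with compound 1 nearest and compound 2 furthest. The underlying steps are a 1.1-fold lower number from compound 1 to compound 2 (0.03 log units; within the scatter), a 3.1-fold higher number from compound 2 to compound 3 (0.49 log units; beyond the scatter) and a 2.9-fold higher number from compound 1 to compound 3 (0.46 log units; beyond the scatter).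

Compound 4 `COc1ccc(-n2cc(C(=O)Nc3ccc(Oc4ccnc5[nH]ccc45)c(F)c3)c(=O)c3ccccc32)cc1` is not yet measured. It differs from compound 3 in one place: 4-methoxyphenyl in place of 4-bromo-2-fluorophenyl on an aromatic nitrogen. Among the measured compounds shown here, two measured steps bear on this change. Removing the fluorine reverses what was seen in a 3.1-fold higher number from compound 2 to compound 3 (0.49 log units; beyond the scatter), a modest step beyond the scatter. On these data alone, exchanging a substituent on that ring, as in a 1.1-fold lower number from compound 1 to compound 2 (0.03 log units; within the scatter), stayed within the scatter, though a methoxy group itself appears nowhere among the measured compounds, so its own contribution is unknown. The expected outcome is therefore a modest step toward lower numbers, back to the level of compound 1 and compound 2.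

In this assay compound 4 is expected to give 800 nM, with a range from 350 nM to 1900 nM. The step this estimate implies is a 2.8-fold lower number from compound 3 to compound 4 (0.44 log units; beyond the scatter).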

Compound 4, half-maximal inhibitory concentration: 6530 nM
The estimate for compound 4 lay 8.2-fold (0.91 log units) below the measured number; measured number outside the range, above it.
By their numbers in this assay, from the lowest: compounds 2 and 1 (each within the scatter of the next); then compound 3; then compound 4.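

In this assay, the aryl group on the aromatic nitrogen proves more sensitive than the bromo and hydrogen pair suggested: bromo in place of hydrogen stayed within the scatter, at a 1.1-fold lower number from compound 1 to compound 2 (0.03 log units; within the scatter), whereas methoxy in place of bromo gives a 9.2-fold higher number from compound 2 to compound 4 (0.96 log units; beyond the scatter) and methoxy in place of hydrogen gives an 8.6-fold higher number from compound 1 to compound 4 (0.93 log units; beyond the scatter). The exchange of 4-bromo-2-fluorophenyl for 4-methoxyphenyl gives a 3.0-fold higher number from compound 3 to compound 4 (0.47 log units; beyond the scatter), so a ring without fluoro does not by itself return the number to the level of compound 1 and compound 2, and compound 4 is the weakest of the four in this assay. No measurement at hand accounts for the loss seen with methoxy.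

On these data alone, whether the rise follows the oxygen of the methoxy group or the group as a whole stays open, and a methyl group, a hydroxyl group or an amine at the same place on the ring would help to separate these readings. Also open, as far as these compounds go, is whether a fluoro added to the 4-methoxyphenyl ring would raise the number as it did from compound 2 to compound 3, or whether that step holds only alongside bromo.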